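From 1,3-benzothiazol-2-yl to 1,3-benzoxazol-2-yl in compound 3

The source may report more compounds than this note shows. Statements on the series, on what has been measured and on what is new or still open speak of the compounds shown alone.

Compound 2 `Cc1ccc(-c2nc3ccccc3s2)cc1NC(=O)c1cc([N+](=O)[O-])ccc1Cl` stands in an ADME assay on HepG2 cells (Homo sapiens) for cytotoxicity, with a stated time of 72 h (on this read-out higher numbers stand for an effect only at larger amounts of compound and lower numbers for an effect already at smaller amounts), only at a limit, > 14000 nM. Compound 1 `O=C(Nc1cccc(-c2nc3ccccc3o2)c1)c1cc([N+](=O)[O-])ccc1Cl`, which carries 1,3-benzoxazol-2-yl, also gives only a limit in this assay, > 25000 nM. Compound 3 `Cc1ccc(-c2nc3ccccc3o2)cc1NC(=O)c1cc([N+](=O)[O-])ccc1Cl` differs from compound 2 by 1,3-benzoxazol-2-yl in place of 1,3-benzothiazol-2-yl on an aromatic carbon, with 1,3-benzoxazol-2-yl in place of 1,3-benzothiazol-2-yl on an aromatic carbon. With compound 1 at the limit > 25000 nM, no step beyond the scatter is expected in this assay, in either direction. The estimated step that the limit leaves unreadable from compound 2 to compound 3 stays within that scatter. For compound 3 the expected value is 20000 nM, with an estimated range of 9000 nM to 40000 nM.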

Compound 3, half-maximal effective concentration: > 14000 nM
Compound 3 gave a limit, no number (the forecaster's own chance of this, stated with the estimate: 75%); the middle value does not contradict the limit.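

Among these compounds, compound 1, compound 2 and compound 3 all give only limits in this assay, and no step from compound 1 or compound 2 to compound 3 can be read. The compounds shown leave open at what concentration any of them reaches a half-maximal effect.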